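The source may hold more compounds than are shown below. What is called first, only, known or untested is meant among the compounds shown, and "the series" means these compounds.

Working notes on the series

- Compound 1 `CCc1ccc(SCc2ccc(/C=C/C(=O)Nc3ccccc3N)cc2)cc1`: "not determined" (no result reported)
- Compound 2 `COc1ccc(SCc2ccc(C(=O)Nc3ccccc3N)cc2)cc1`: 2390 nM

In a functional assay on HeLa cells (Homo sapiens) for antiproliferative activity, read by CCK-8 assay, with a stated time of 72 h (on this read-out lower numbers stand for stronger inhibition and higher numbers for weaker inhibition), compound 2 gives 2390 nM. Among the compounds with values here, this is the only number so far, so compound 2 cannot yet be ranked as strong or weak against any neighbour. Compound 1 offers no comparison, since no result was reported for it. Within the data shown here, no pair of measured compounds exists, and the data therefore do not show how much a change of any kind moves this read-out.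

The next compound to be tested is compound 3 `Nc1ccccc1NC(=O)c1ccc(CSc2cccc(F)c2)cc1`. It has 3-fluorophenyl in place of 4-methoxyphenyl on a sulfur, and the rest of the structure matches compound 2. Among the measured compounds shown here, with no measured step to guide it, the working expectation is no clear direction and no shift beyond the usual scatter, anchored on compound 2 at 2390 nM. The estimated change is a 1.2-fold lower number from compound 2 to compound 3 (0.08 log units; within the scatter), which is small and carries wide uncertainty. In this assay the expected value for compound 3 is 2000 nM, with an estimated range of 650 nM to 6500 nM.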

Compound 3, half-maximal inhibitory concentration: 3240 nM
Compound 3: middle estimate off by 1.6-fold (0.21 log units), on the low side; measured number inside the range.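

In this assay the series now has its first measured step, a 1.4-fold higher number from compound 2 to compound 3 (0.13 log units; within the scatter), for 3-fluorophenyl in place of 4-methoxyphenyl on a sulfur. On a sulfur whose other neighbours are a saturated chain carbon, these two aromatic groups therefore cannot be told apart in this read-out, although the change removes the oxygen and the hydrogen-bond acceptor of the 4-methoxyphenyl group and brings in a fluorine. No measurement shown bears on why the two compounds read alike.

Within the data shown here, the single step covers only this one exchange on the sulfur, so it leaves open whether any replacement at this place can move the number beyond the usual scatter. A phenyl ring carrying an amine or a carboxylic acid, or a longer saturated chain in place of the aromatic group, would test this place more widely, and changes to the shared core remain a separate question.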